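Swapping the benzyl halide on the sulfur of compound 1

A few compounds are considered here, and "the series" means these few. Any claim that something is new, unique, unknown or untested is made for them only; others in the source may bear on it.

Compound 1 `O=C(O)c1ccc(C(=O)/C(=C\c2ccc(F)c([N+](=O)[O-])c2)SCc2ccc(F)cc2)cc1` is the stronger of the two measured compounds in a functional assay on DU-145 cells (Homo sapiens) for inhibition, read by trypan blue exclusion, with a stated time of 96 h (a higher number here means a weaker inhibitor of growth, a lower number a stronger inhibitor of growth), where compound 1 gives 1000 nM. Within the data shown here, its only measured neighbour is compound 2 `CN(C)c1ccc(/C=C(/SCc2ccc(F)cc2)C(=O)c2ccc(C(=O)O)cc2)cc1`, which in this assay gives 10000 nM; the change between them is a 10-fold higher number from compound 1 to compound 2 (1.00 log units; beyond the scatter), and it alters the aryl group on the double-bonded chain carbon, not the group on the sulfur.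

Compound 3 `O=C(O)c1ccc(C(=O)/C(=C\c2ccc(F)c([N+](=O)[O-])c2)SCc2ccccc2Cl)cc1` differs from compound 1 elsewhere: 2-chlorophenyl in place of 4-fluorophenyl on a saturated chain carbon bound to a sulfur. Among the measured compounds shown here, no measured step touches this part of the shared core, so the step from compound 1 to compound 2 does not bear on it and nothing in the data points in either direction. The expectation is therefore a step within the scatter, no change at the digits printed from compound 1 to compound 3 (within the scatter). Compound 3 is estimated to give 1000 nM in this assay, within a range from 300 nM to 3500 nM.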

Compound 3, concentration for 50% growth inhibition: 1000 nM
Compound 3: the middle estimate sits on the measured number at the digits printed, and the stated range covers the measured number.
By their numbers in this assay, from the lowest: compounds 1 and 3 (each within the scatter of the next); then compound 2.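

In this assay, putting 2-chlorophenyl in place of 4-fluorophenyl on a saturated chain carbon bound to a sulfur gives no change at the digits printed from compound 1 to compound 3 (within the scatter). Among these compounds, the earlier step changed only the aryl group on the double-bonded chain carbon, so this is the first reading on the group at the sulfur end, and here one halogen-bearing phenyl ring stands in for another with no visible effect on growth inhibition. Nothing available explains why these two groups read alike.

This single swap changes both the halogen and its place on the ring, so the two changes cannot be told apart. On these data alone, whether the number would also hold with a very different group here, such as a phenyl ring carrying an amine or a carboxylic acid, or a longer chain, remains open.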